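A few compounds are considered here, and "the series" means these few. Any claim that something is new, unique, unknown or untested is made for them only; others in the source may bear on it.

Measured so far in a functional assay on MKN-74 cells (Homo sapiens) for antiproliferative activity, with a stated time of 24 h (a lower number here means a stronger inhibitor, a higher number a weaker inhibitor), for the series:
- compound 1 `Cc1ccccc1CN1CCc2c(sc(NC(=O)c3ccccc3Cl)c2C(N)=O)C1` gives > 50000 nM as a limit of the assay
- compound 2 `NC(=O)c1c(NC(=O)c2ccccc2Cl)sc2c1CCN(C(=S)Nc1cccc3ccccc13)C2` gives 20700 nM as a measured number

For the measured compounds named here, compound 2 holds the only number so far, while compound 1 sits at a limit. Compound 3 `NC(=O)c1c(NC(=O)c2ccccc2Cl)sc2c1CCN(C(=S)Nc1ccccc1Br)C2` has 2-bromophenyl in place of naphthalen-1-yl on an amide-type nitrogen, a difference that counts as 2-bromophenyl in place of naphthalen-1-yl on an amide-type nitrogen in full. Going by the values given here, no measured step covers this change, so the expectation rests on compound 2 at 20700 nM and is for no step beyond the scatter in this assay here. The expected move is a 1.2-fold higher number from compound 2 to compound 3 (0.08 log units; within the scatter) in this reading. For compound 3 the estimated value is 25000 nM with an expected range from 9000 nM to 50000 nM in this measurement.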

Compound 3, half-maximal inhibitory concentration: 10800 nM
Beside the measured number, compound 3's estimate is 2.3-fold (0.36 log units) above it, and the stated range covers the measured number.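

Notes on this assay: on the amide-type nitrogen, 2-bromophenyl with one six-membered aromatic ring in place of naphthalen-1-yl with two gives a 1.9-fold lower number from compound 2 to compound 3 (0.28 log units; within the scatter), so the second ring is not required for a measurable number in this pair. The group change on the ring amine nitrogen gives an at least 4.6-fold lower number from compound 1 to compound 3 (0.66 log units; beyond the scatter). Compound 1 stands at a limit of the assay, > 50000 nM.

Still open, as far as these compounds go, is how a plain phenyl, a methoxyphenyl or a short alkyl chain would read on the same nitrogen. From the compounds shown here alone, the effect of a carbonyl in place of the thiocarbonyl is also open.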